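From vinyl to pent-1-en-1-yl on the carbonyl carbon

The source may report more compounds than this note shows. Statements on the series, on what has been measured and on what is new or still open speak of the compounds shown alone.

In a functional assay on A549 cells (Homo sapiens) for antiproliferative activity, read by MTT assay, with a stated time of 72 h (a lower number here means a stronger inhibitor, a higher number a weaker inhibitor), compound 3 `C=CC(=O)Nc1cccc(Oc2nc(Nc3ccc(OC)cc3)nc3c2CSCC3)c1` gives 4220 nM, within the scatter of compound 2 `CCC/C=C/C(=O)Nc1cccc(Oc2nc(Nc3cccc(C#N)c3)nc3c2CSCC3)c1` at 5790 nM. For the measured compounds named here, compound 1 `C=CC(=O)Nc1cccc(Oc2nc(Nc3cccc(OC)c3)nc3c2CSCC3)c1` gives 10100 nM, and the only measured step is a 2.4-fold lower number from compound 1 to compound 3 (0.38 log units; beyond the scatter). That step concerns the methoxyphenyl group on nitrogen and does not touch the carbonyl side. Compound 4 `CCC/C=C/C(=O)Nc1cccc(Oc2nc(Nc3ccc(OC)cc3)nc3c2CSCC3)c1` differs from compound 3 as follows: pent-1-en-1-yl in place of vinyl on a carbonyl carbon. Going by the values given here, no measured step isolates this change. Compound 2 carries pent-1-en-1-yl, but it also has a different aryl group and no vinyl partner. No step beyond the scatter is therefore expected in this assay, and no direction can be assigned. The expected step is a 1.1-fold higher number from compound 3 to compound 4 (0.03 log units; within the scatter). The estimate for compound 4 is 4500 nM, with an expected range of 1800 nM to 11000 nM.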

Compound 4, half-maximal inhibitory concentration: 11900 nM
Compound 4: the middle estimate sits 2.6-fold (0.42 log units) below what was measured, outside the stated range (above it).
By their numbers in this assay, from the lowest: compounds 3, 2, 1 and 4 (each within the scatter of the next, the first and the last beyond it).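

In this assay, the carbonyl carbon proves sensitive to its substituent: with 4-methoxyphenyl held, pent-1-en-1-yl in place of vinyl gives a 2.8-fold higher number from compound 3 to compound 4 (0.45 log units; beyond the scatter). With pent-1-en-1-yl held, 4-methoxyphenyl in place of 3-cyanophenyl on a nitrogen on an aromatic ring gives a 2.1-fold higher number from compound 2 to compound 4 (0.31 log units; beyond the scatter), so the aryl group also counts in the pent-1-en-1-yl amides. No evidence on the cause of either step is available. Open, as far as these compounds go, is whether the vinyl to pent-1-en-1-yl step holds with 3-cyanophenyl on nitrogen. Also open, from the compounds shown here alone, is whether prop-1-en-1-yl, or a chain carrying an amine, reads closer to vinyl or to pent-1-en-1-yl.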